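This account rests on a few compounds, and the source may have more. Where it says the series, first, only, none or still open, it means among the compounds named here.

The measured compounds and their values:

Compound 1, `Cc1cccc(/C(N)=N/NC(=S)N2CCSCC2)n1`: 20.6%
Compound 2, `Cc1ccnc(/C(N)=N/NC(=S)N2CCN(c3ccccn3)CC2)c1`: 32.8%
Compound 3, `N/C(=N\NC(=S)N1CCSCC1)c1ccccn1`: 29%

All three were tested in a functional assay on MCF7 cells (Homo sapiens) for cytotoxicity, read by MTT assay, with a stated time of 72 h, tested at 3 uM; on this read-out higher numbers stand for more inhibition of growth at the one concentration tested and lower numbers for less inhibition of growth. Compound 1 and compound 3 share a core and differ in one place: hydrogen in place of methyl on an aromatic carbon. This change gave a number 8.4 percentage points higher from compound 1 to compound 3 (within the scatter). Compound 2 carries a different core from compound 1, and how the two cores differ is not broken down here. Among the three, compound 2 shows the highest number; against compound 3 the gap is within the scatter, while against compound 1 it lies beyond it, so compound 2 and compound 3 cannot be ranked against each other on these data.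

Compound 4, `N/C(=N\NC(=S)N1CCN(c2ccccn2)CC1)c1ccccn1`, has not yet been measured in this assay. It differs from compound 2 by hydrogen in place of methyl on an aromatic carbon. Among the compounds with values here, this is the same kind of change as the one from compound 1 to compound 3, but not the same: in compound 1 the methyl sits next to the ring nitrogen and meta to a large group, whereas in compound 2 it sits meta to a large group and opposite the ring nitrogen.

The step from compound 2 to compound 4 in this assay is expected to be a number 4.2 percentage points higher from compound 2 to compound 4 (within the scatter), because the same kind of change on the other core gave a number 8.4 percentage points higher from compound 1 to compound 3 (within the scatter), a small step that stayed within the scatter. Compound 4 is therefore estimated to give 37%, most likely between 25% and 49%.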

Compound 4, percent growth inhibition at one concentration: 37.2%
Beside the measured number, compound 4's estimate is 0.2 percentage points below it; the measured number falls inside the stated range.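

In this assay, hydrogen in place of methyl on an aromatic carbon gave a number 4.4 percentage points higher from compound 2 to compound 4 (within the scatter), and the same change on the two cores compares as follows: the same change on two cores in this assay, a number 8.4 percentage points higher (within the scatter) from compound 1 to compound 3 and a number 4.4 percentage points higher (within the scatter) from compound 2 to compound 4, 4 percentage points apart, within the scatter of two such steps. In these two pairs, then, the step carried over from the core of compound 1 to the core of compound 2 with no difference in size that the data can resolve, even though the methyl does not sit in the same place in the two pairs. Both steps lie within the scatter, however, so the pairs do not show that the change moves growth inhibition at all, only that nothing separates its size on these two cores, and they say nothing about other cores or other concentrations.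

Only methyl and hydrogen appear on this aromatic carbon, so the compounds shown leave open what a chlorine, a methoxy group, an amine or a longer alkyl chain would do there. They also leave open whether a larger group at this place would produce a step beyond the scatter, and whether such a step would carry from one core to the other as this small one appears to.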